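The source may report more compounds than this note shows. Statements on the series, on what has been measured and on what is new or still open speak of the compounds shown alone.

Measured compounds:
compound 1, `CCCCc1ccc(CNC(=O)N(C)C)c(=O)n1Cc1ccc(-c2ccccc2-c2nn[nH]n2)cc1`: 28%
compound 2, `CCCCc1ccc(CN)c(=O)n1Cc1ccc(-c2ccccc2-c2nn[nH]n2)cc1`: 2.8%

Within the data shown here, in a functional assay on the whole organism (artery) for inhibition, with Rattus norvegicus as the target, at a dose of 3 mg/kg by the intraduodenal route (a lower number here means less inhibition, a higher number more inhibition at the dose given (going by the name of the read-out)), compound 2 stands lowest of the two numbers; the only measured step, a number 25.2 percentage points lower from compound 1 to compound 2 (beyond the scatter), shows that stripping the amine down to a bare hydrogen cost inhibition beyond the scatter. Compound 3, `CCCCc1ccc(CN(C)S(=O)(=O)c2ccccc2)c(=O)n1Cc1ccc(-c2ccccc2-c2nn[nH]n2)cc1`, differs from compound 2 in one place: methyl(phenylsulfonyl)amino in place of amino on a saturated chain carbon bound to an aromatic carbon. That is again a capping of the same amine, so the step that bears on it is a number 25.2 percentage points lower from compound 1 to compound 2 (beyond the scatter), read in reverse. A rise of similar size is therefore expected in this assay, though the new cap is not the old one. Compound 3 is estimated at 25%, between 5% and 50%, an expected step of a number 22.2 percentage points higher from compound 2 to compound 3 (beyond the scatter).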

Compound 3, a percentage reported as inhibition, in the whole organism at one dose (the size of the read-out at that dose, not a potency): 68.7%
Estimate against measurement, compound 3: 43.7 percentage points below; measured number above the stated range.
By their numbers in this assay, from the lowest: compound 2; then compound 1; then compound 3.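

In this assay the steps of a number 65.9 percentage points higher from compound 2 to compound 3 (beyond the scatter) and of a number 40.7 percentage points higher from compound 1 to compound 3 (beyond the scatter) show that capping this amine is not enough on its own: the choice of cap matters. At this saturated chain carbon, methyl(phenylsulfonyl)amino gives more inhibition at the dose given than (dimethylcarbamoyl)amino. Nothing measured here explains this gain. As far as these compounds go, it remains open whether the gain comes from the phenyl ring or from the methyl on the nitrogen. A methylsulfonyl cap in place of phenylsulfonyl, or a phenylsulfonylamino group without that methyl, would help separate the two.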